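A nitrile replaces a methyl on a diaryl ether

This account rests on a few compounds, and the source may have more. Where it says the series, first, only, none or still open, it means among the compounds named here.

Three compounds sharing one core have been assessed in an ADME assay on MT4 cells (Homo sapiens) for cytotoxicity, read by MTT assay, with a stated time of 5 days; a lower number here means that less compound is tolerated, a higher number that more compound is tolerated. Compound 1 `Cc1cc(C)c(Oc2cc(NCCn3ccc(=O)[nH]c3=O)nc(Cl)n2)c(C)c1` gives 76400 nM in this assay. Compound 3 `Cc1cc(C)cc(Oc2cc(NCCn3ccc(=O)[nH]c3=O)nc(Cl)n2)c1` gives 99500 nM, and the step of a 1.3-fold higher number from compound 1 to compound 3 (0.11 log units; within the scatter) moves the reading by too little to separate the two. Compound 2 `Cc1cc(/C=C/C#N)cc(C)c1Oc1ccnc(NCCn2ccc(=O)[nH]c2=O)n1` returns only a limit in this assay, > 309000 nM, and so supplies no number. Among the two numbers shown, compound 1 stands lowest, with compound 3 as its nearest neighbour and within the scatter of it.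

Compound 4 `Cc1cc(C#N)cc(C)c1Oc1cc(NCCn2ccc(=O)[nH]c2=O)nc(Cl)n1` has not yet been measured in this assay. It differs from compound 1 by cyano in place of methyl on an aromatic carbon. Going by the values given here, no measured step covers this exchange: the only step available, from compound 1 to compound 3, removed a methyl rather than replacing one, and it stayed within the scatter. The limit of > 309000 nM in this assay, at which 1 of the 3 values shown sits, belongs to a compound of a different core and carries no number to lean on. Compound 4 is therefore expected to sit near compound 1, with the step of a 1.2-fold higher number from compound 1 to compound 4 (0.09 log units; within the scatter) expected to remain within the scatter. For compound 4 the estimate in this assay is 95000 nM, with a range from 40000 nM to 250000 nM.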

Compound 4, half-maximal cytotoxic concentration: 27900 nM
Compound 4: middle estimate off by 3.4-fold (0.53 log units), on the high side; the whole stated range lies above it.
By their numbers in this assay, from the lowest: compound 4; then compounds 1 and 3 (each within the scatter of the next). At a limit, above all of these: compound 2.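

In this assay, cyano in place of methyl on an aromatic carbon gives a 2.7-fold lower number from compound 1 to compound 4 (0.44 log units; beyond the scatter). This is a modest step, but unlike a 1.3-fold higher number from compound 1 to compound 3 (0.11 log units; within the scatter), it lies beyond the scatter, so the place para to a large group and meta to two methyl groups is one where a single exchange changes how much compound the cells tolerate. Nothing measured on these compounds bears on why the number falls with this exchange.

One exchange at this carbon cannot show whether the fall is particular to cyano, and an amine, a carboxylic acid or a longer chain at the same place would be needed to show how far it extends. Compound 2 gives > 309000 nM, which is a limit and not a number, and as it differs from compound 4 in more than one place, it leaves open how the extended cyano-bearing chain on its aromatic ring would read on the core of compound 4.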